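This account rests on a few compounds, and the source may have more. Where it says the series, first, only, none or still open, it means among the compounds named here.

Compound 1 `O=S(=O)(NC1=NCCN1C(=S)SN1CCn2c1nsc2=S)c1ccc(Cl)cc1` was examined in a functional assay on KYSE-510 cells (Homo sapiens) for antiproliferative activity, read by crystal violet staining, with a stated time of 96 h; on this read-out lower numbers stand for stronger inhibition of growth and higher numbers for weaker inhibition of growth. In this assay compound 1 gives >= 20000 nM, which is a limit of the assay and not a number. Compound 2 `O=S(=O)(NC1=NCCN1C(=S)SN1CCn2c1nsc2=S)c1ccc(-c2ccccc2)cc1` carries phenyl in place of chloro on an aromatic carbon. In this assay compound 2 gives >= 20000 nM, again a limit rather than a measured number. For the measured compounds named here, the only measured step that bears on the next change is a step that the two limits leave unreadable from compound 1 to compound 2, and it gives no size because both compounds rest on (the limit of >= 20000 nM in this assay, at which 2 of the 2 values shown sit). Compound 2 thus stands at the assay limit, with no readable step beneath it.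

Compound 3 `O=S(=O)(NC1=NCCN1C(=S)SN1CCn2c1nsc2=S)c1ccc(Oc2ccccc2)cc1` carries phenoxy in place of phenyl on an aromatic carbon. Going by the values given here, with the single related step unreadable, no measured basis exists for a step of any particular size or direction, and compound 3 is expected to remain at the limit. Compound 3 is estimated at 30000 nM, between 8000 nM and 100000 nM. The step this expectation implies is a step that the limit leaves unreadable from compound 2 to compound 3.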

Compound 3, concentration for 50% growth inhibition: >= 20000 nM
Compound 3 was reported as a limit (the forecaster's own chance of this, stated with the estimate: 75%); the middle value lies beyond the limit too.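

No step among compound 1, compound 2 and compound 3 can be read in this assay, because all three rest on a limit of the assay: the limit of >= 20000 nM in this assay, at which 3 of the 3 values shown sit.

The compounds shown leave open whether chloro, phenyl and phenoxy differ at all in their inhibition of growth.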